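Arylaminothiazolone esters: notes on MCF7 growth inhibition

This account rests on a few compounds, and the source may have more. Where it says the series, first, only, none or still open, it means among the compounds named here.

Measured so far:
compound 1 `CCOC(=O)C1=C(Nc2ccccc2)S/C(=C\c2cccc(C(=O)O)c2)C1=O`: < 10%
compound 2 `CCOC(=O)C1=C(Nc2ccc(C)cc2)S/C(=C\c2ccc[nH]2)C1=O`: < 10%

In a functional assay on MCF7 cells (Homo sapiens) for inhibition, read by MTT assay, with a stated time of 72 h, tested at 10 uM (on this read-out lower numbers stand for less inhibition and higher numbers for more inhibition at the one concentration tested (going by the name of the read-out)), compound 1 gives < 10%, which is a limit of the assay rather than a number. Compound 2 also returns only a limit in this assay. Among the measured compounds shown here, the sole evidence is the limit of < 10% in this assay, at which 2 of the 2 values shown sit, so compound 1 stands at the floor of the read-out, and no step between measured compounds can be drawn. Compound 3 `CCOC(=O)C1=C(Nc2ccccc2)S/C(=C\c2cc3ncccc3[nH]2)C1=O` differs from compound 1 by a group of 9 heavy atoms (7 carbon, 2 nitrogen; one five-membered aromatic ring with 1 hetero atom, one six-membered aromatic ring with 1 hetero atom) in place of a group of 9 heavy atoms (7 carbon, 2 oxygen; one six-membered aromatic ring of carbon only), on a double-bonded chain carbon bound to a double-bonded ring carbon. With nothing measured to guide it, the expected step that the limit leaves unreadable from compound 1 to compound 3 is none beyond the scatter. Compound 3 is therefore estimated at 8%, between 0% and 25%.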

Compound 3, a percentage reported as inhibition, at one concentration (the size of the read-out at that concentration, not a potency): 42.2%
Compound 3: middle estimate off by 34.2 percentage points, on the low side; measured number outside the range, above it.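

At the double-bonded chain carbon bound to a double-bonded ring carbon, the substituent can lift the read-out off its floor: in this assay, replacing 3-carboxyphenyl with the group carrying one five-membered and one six-membered aromatic ring gives a number at least 32.2 percentage points higher from compound 1 to compound 3 (beyond the scatter). The two groups match in heavy atoms, donors and acceptors, so these counts alone do not account for the step. The value of compound 1 is a limit, so the full size of the step stays unfixed: the limit of < 10% in this assay, at which 2 of the 3 values shown sit.

Which part of the entering group carries the step remains open. Also open, going by these compounds, is whether an amide in place of the ester would retain the inhibition.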